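Halogen out, methoxy in: expecting compound 4

This account rests on a few compounds, and the source may have more. Where it says the series, first, only, none or still open, it means among the compounds named here.

Measured in a functional assay on HeLa cells (Homo sapiens) for antiproliferative activity, read by MTT assay, with a stated time of 72 h; a lower number here means a stronger inhibitor, a higher number a weaker inhibitor:
- compound 1 `COc1cc(-c2ncnn2-c2cccc(F)c2)cc(OC)c1OC`: > 10000 nM (a limit)
- compound 2 `COc1cc(-n2ncnc2-c2ccc(C)cc2)cc(OC)c1OC`: 250 nM
- compound 3 `COc1cc(-n2ncnc2-c2ccc(Cl)cc2)cc(OC)c1OC`: > 10000 nM (a limit)

Compound 1 stands at the limit of > 10000 nM in this assay, at which 2 of the 3 values shown sit. Only compound 2 gives a number, 250 nM.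

Compound 4 `COc1ccc(-n2ncnc2-c2cc(OC)c(OC)c(OC)c2)cc1` keeps the core of compound 1 and differs from it in one place: 4-methoxyphenyl in place of 3-fluorophenyl on an aromatic nitrogen. Going by the values given here, no measured step covers this change directly. The nearest evidence is an at least 40-fold higher number from compound 2 to compound 3 (1.60 log units; beyond the scatter), a large step beyond the scatter, with chloro in place of methyl on an aromatic carbon. Among the three measured compounds, the two that carry a halogen, compound 1 and compound 3, sit at the limit, while compound 2 has no halogen and gives a number. Compound 4 has no halogen either, with 4-methoxyphenyl in place of 3-fluorophenyl. Going by an at least 40-fold higher number from compound 2 to compound 3 (1.60 log units; beyond the scatter), a single change on an aromatic group can be large, so a step beyond the scatter towards a lower number is expected in this assay. Its size is poorly fixed, and compound 4 may yet remain at the limit. The expected step is an at least 6.6-fold lower number from compound 1 to compound 4 (0.82 log units; beyond the scatter). For compound 4 the estimated value is 1500 nM, with an expected range from 150 nM to 10000 nM.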

Compound 4, half-maximal inhibitory concentration: > 10000 nM
Compound 4 was reported as a limit (the forecaster's own chance of this, stated with the estimate: 35%); middle value at least 6.6-fold (0.82 log units) away from the limit.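

Compound 4 joins compound 1 at the same limit, which is not a number: the limit of > 10000 nM in this assay, at which 3 of the 4 values shown sit. Going by these compounds alone, no step from compound 1 to compound 4 can be read from these two limits. The compounds shown leave open whether 4-methoxyphenyl in place of 3-fluorophenyl changes anything at all in this assay.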